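This account rests on a few compounds, and the source may have more. Where it says the series, first, only, none or still open, it means among the compounds named here.

Compound 2 `COc1cc(/C=C2\SC(=O)NC2=O)ccc1OCC1(C)CCc2c(C)c(OCC=C(C)C)c(C)c(C)c2O1` carries a methoxy group on the aromatic carbon where compound 1 `CC(C)=CCOc1c(C)c(C)c2c(c1C)CCC(C)(COc1ccc(/C=C3\SC(=O)NC3=O)cc1)O2` has only hydrogen. In a functional assay on MCF7 cells (Homo sapiens), tested at 7.5 uM (a lower number here means a stronger effect, a higher number a weaker effect of the compound at the concentration tested), compound 1 gives 5%, while compound 2 gives 54%. Among the compounds with values here, of the two numbers known so far, compound 2 stands highest, with compound 1 its nearest neighbour, the two separated by a number 49 percentage points higher from compound 1 to compound 2 (beyond the scatter), a step beyond the scatter. Compound 3 `CC(C)=CCOc1c(C)c(C)c2c(c1C)CCC(C)(COc1ccc(/C=C3\SC(=O)NC3=O)cc1Br)O2` differs from compound 2 by bromo in place of methoxy on an aromatic carbon. Within the data shown here, the only measured step that bears on this change is the one from hydrogen to methoxy on the same aromatic carbon, a number 49 percentage points higher from compound 1 to compound 2 (beyond the scatter), which was large. Among the measured compounds shown here, that step shows the read-out responds strongly to what sits on this carbon, but no measured pair tells how bromo compares with methoxy there. Taking the methoxy away is therefore expected to move the number downward again, yet bromo is not hydrogen, so the step from compound 2 to compound 3 is estimated as a number 22 percentage points lower from compound 2 to compound 3 (beyond the scatter), with wide uncertainty. Compound 3 is expected to give 32%, within a range of 8% to 58%.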

Compound 3, a percentage reported as activity, at one concentration (the size of the read-out at that concentration, not a potency): 53%
For compound 3 the middle estimate is 21 percentage points below the measured one; the range from low to high includes it.
By their numbers in this assay, from the lowest: compound 1; then compounds 3 and 2 (each within the scatter of the next).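

In this assay, the swap of methoxy for bromo on this aromatic carbon leaves the read-out unchanged within the scatter, with a number 1 percentage points lower from compound 2 to compound 3 (within the scatter), while the comparison with hydrogen at the same place gives a number 48 percentage points higher from compound 1 to compound 3 (beyond the scatter). The large step seen earlier is therefore not particular to methoxy: two different groups on this carbon, ortho to a large group, read alike, and both stand apart from hydrogen on the shared core. Nothing available explains why these two groups match or why either differs so much from hydrogen.

The compounds shown leave open whether any group on this carbon produces the same step or only some do, and a fluoro, a methyl, an amine or a carboxylic acid there would each put that to the test, as would a longer chain such as ethoxy in place of methoxy. They also leave open whether bromo and methoxy would still match at other concentrations, since the read-out here comes from a single one.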